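Swapping pyridin-2-yl for thiophen-3-yl on two cores

This account rests on a few compounds, and the source may have more. Where it says the series, first, only, none or still open, it means among the compounds named here.

Measured so far:
Compound 1 `COc1ccc(Nc2nccc(-c3ccsc3)n2)cc1` gives 15600 nM in a functional assay for inhibition, with Homo sapiens as the target; on this read-out lower numbers stand for stronger inhibition and higher numbers for weaker inhibition.
Compound 2 `COc1ccc(Nc2nccc(-c3ccccn3)n2)cc1` gives 8300 nM in this assay.
Compound 3 `CCc1cccc(Nc2nccc(-c3ccccn3)n2)c1` gives 1400 nM in this assay.

Compound 1 differs from compound 2 by one change, (thiophen-3-yl in place of pyridin-2-yl on an aromatic carbon), and that change made a 1.9-fold higher number from compound 2 to compound 1 (0.27 log units; within the scatter). Compound 3 has the lowest of the three numbers; how its core differs from that of compound 2 is not broken down here. Compound 4 `CCc1cccc(Nc2nccc(-c3ccsc3)n2)c1` carries the same change on the core of compound 3, namely (thiophen-3-yl in place of pyridin-2-yl on an aromatic carbon).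

For compound 4 the expected step is a 1.9-fold higher number from compound 3 to compound 4 (0.29 log units; within the scatter), resting on the measured pair because a 1.9-fold higher number from compound 2 to compound 1 (0.27 log units; within the scatter). The estimate for compound 4 in this assay is 2700 nM, expected to fall between 1000 nM and 8000 nM.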

Compound 4, half-maximal inhibitory concentration: 1100 nM
The estimate for compound 4 lay 2.5-fold (0.39 log units) above the measured number, and the stated range covers the measured number.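

On the second core, thiophen-3-yl in place of pyridin-2-yl gave a 1.3-fold lower number from compound 3 to compound 4 (0.10 log units; within the scatter) in this assay and so left the number within the scatter. Set beside the step on the first core, this one does not differ by more than repeated measurements could produce: the same change on two cores in this assay, a 1.9-fold higher number (0.27 log units; within the scatter) from compound 2 to compound 1 and a 1.3-fold lower number (0.10 log units; within the scatter) from compound 3 to compound 4, 2.4-fold (0.38 log units) apart, within the scatter of two such steps. On these two cores the swap carries over as a change too small to read, but two such small steps cannot show that it would stay small on any other core, and they do not explain why it is small.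

The compounds shown leave open whether an amine or a carboxylic acid at this place would shift the number beyond the scatter. On these data alone, whether a longer chain in place of the ethyl group would change the number also stays open.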